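Swapping Trifluoromethyl for Chloro on the Outer Aryl Ring

The source may report more compounds than this note shows. Statements on the series, on what has been measured and on what is new or still open speak of the compounds shown alone.

Compound 2 `COc1cc2cc(Oc3ccc(NC(=O)Nc4ccc(Cl)c(C(F)(F)F)c4)cc3)c(C)nc2cc1OC` carries a 4-chloro-3-(trifluoromethyl)phenyl group at one end of the shared core. Going by the values given here, in a functional assay on MOLT-4 cells (Homo sapiens) for inhibition, read by sulforhodamine B assay, with a stated time of 48 h (a higher number here means a weaker inhibitor of growth, a lower number a stronger inhibitor of growth), compound 2 gives 5490 nM, the lowest of the two numbers measured so far, though only by a margin that sits within the scatter. Its neighbour compound 1 `COc1cc2cc(Oc3ccc(NC(=O)Nc4cccc(C(F)(F)F)c4)cc3)c(C)nc2cc1OC` lacks the chloro; in this assay compound 1 gives 6870 nM. Among the compounds with values here, the one measured step, a 1.3-fold lower number from compound 1 to compound 2 (0.10 log units; within the scatter), was too small to count as a real change.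

Compound 3 `COc1cc2cc(Oc3ccc(NC(=O)Nc4ccc(Cl)c(Cl)c4)cc3)c(C)nc2cc1OC` is the next variation: chloro in place of trifluoromethyl on an aromatic carbon, so that the 4-chloro-3-(trifluoromethyl)phenyl becomes a 3,4-dichlorophenyl. Within the data shown here, no measured step exchanges a trifluoromethyl for a chloro, so the only guidance is that the single measured change on this ring, from compound 1 to compound 2, moved nothing beyond the scatter. The expectation for this assay is therefore a step of a 1.1-fold higher number from compound 2 to compound 3 (0.04 log units; within the scatter), nothing beyond the scatter in either direction. Compound 3 is expected to give 6000 nM, with a range from 2500 nM to 14000 nM.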

Compound 3, concentration for total growth inhibition: 22800 nM
Beside the measured number, compound 3's estimate is 3.8-fold (0.58 log units) below it; the whole stated range lies below it.
By their numbers in this assay, from the lowest: compounds 2 and 1 (each within the scatter of the next); then compound 3.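

In this assay, this position proves sensitive to which group it carries: the earlier step on this ring, the added chloro, stayed within the scatter, whereas chloro in place of trifluoromethyl gives a 4.2-fold higher number from compound 2 to compound 3 (0.62 log units; beyond the scatter). The comparison with the compound lacking the added chloro points the same way, with a 3.3-fold higher number from compound 1 to compound 3 (0.52 log units; beyond the scatter), and with both steps beyond the scatter, compound 3 is the weakest inhibitor of growth of the three. Nothing available here explains why trifluoromethyl and chloro differ at this place on the ring.

Going by these compounds, with only these two groups compared at this position, it remains open whether trifluoromethyl is specially favoured or chloro specially disfavoured, and a methyl, a bromo, a methoxy or a nitrile there would help to separate the two readings. On these data alone, it also remains open whether exchanging trifluoromethyl for chloro would give a step of similar size on an outer ring without the 4-chloro group.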